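The compounds below may be only part of what the source reports. "The series", "measured", "known", "first", "only" and "open" are said of these compounds alone.

Three compounds of this series have numbers in a functional assay on NCI-H522 cells (Homo sapiens) for inhibition, read by sulforhodamine B assay, with a stated time of 48 h; on this read-out higher numbers stand for weaker inhibition of growth and lower numbers for stronger inhibition of growth. Compound 1 `COc1cc(-c2nn(-c3cccc(NC(=O)Nc4cc(C(F)(F)F)cc(C(F)(F)F)c4)c3)cc2-c2ccncc2)ccc1Cl` gives 1800 nM. Compound 2 `COc1cc(-c2nn(-c3cccc(NC(=O)c4cccc(C(F)(F)F)c4)c3)cc2-c2ccncc2)ccc1Cl` gives 3850 nM, the second highest of the three; its nearest neighbour is compound 1, whose number is lower by a margin that lies beyond the usual scatter. Compound 3 `O=C(Nc1cccc(-n2cc(-c3ccncc3)c(-c3ccc(Cl)c(O)c3)n2)c1)Nc1ccc(Cl)c(Cl)c1` gives 10600 nM, the highest of the three, and the gap from compound 2 to compound 3 also lies beyond the scatter. No pair among these three differs in only one place, so none of their gaps can be tied to a single change.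

Compound 4 `COc1cc(-c2nn(-c3cccc(NC(=O)Nc4cccc(C(F)(F)F)c4)c3)cc2-c2ccncc2)ccc1Cl` has not been measured. It differs from compound 2 in one place: (3-(trifluoromethyl)phenyl)amino in place of 3-(trifluoromethyl)phenyl on a carbonyl carbon. The carbonyl thereby becomes part of a urea, as in compound 1 and compound 3, rather than an amide. Compound 1, which carries a urea, shows 1800 nM, while compound 2 with its amide shows 3850 nM, but compound 1 also carries a second trifluoromethyl, so that comparison is not clean. A modest step toward a lower number is expected, a 1.5-fold lower number from compound 2 to compound 4 (0.19 log units; within the scatter). Compound 4 is estimated at 2500 nM, within a range from 1000 nM to 6500 nM.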

Compound 4, concentration for total growth inhibition: 2430 nM
Compound 4: the middle estimate sits 1.0-fold (0.01 log units) above what was measured; low and high end bracket the measured number.
By their numbers in this assay, from the lowest: compounds 1, 4 and 2 (each within the scatter of the next, the first and the last beyond it); then compound 3.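

In this assay the entry of (3-(trifluoromethyl)phenyl)amino in place of 3-(trifluoromethyl)phenyl on a carbonyl carbon gives a 1.6-fold lower number from compound 2 to compound 4 (0.20 log units; within the scatter) and so does not separate the urea of compound 4 from the amide of compound 2, even though the entering group brings a hydrogen-bond donor and the leaving group has none. Hydrogen in place of trifluoromethyl on an aromatic carbon gives a 1.4-fold higher number from compound 1 to compound 4 (0.13 log units; within the scatter) in the same read-out, so compound 4 links compound 1 and compound 2 by two single changes, neither of which reaches beyond the scatter on its own. Nothing at hand explains the size of either step.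

On these data alone, it remains open how this position would respond to a methylene or an ether oxygen in place of the amino nitrogen of compound 4, or to a nitrile or a methoxy group in place of its trifluoromethyl. Compound 3 still differs from every other compound in more than one place, so the separate contributions of its hydroxyl and its two chlorines to its number remain unresolved.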